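A few compounds are considered here, and "the series" means these few. Any claim that something is new, unique, unknown or untested is made for them only; others in the source may bear on it.

Measured so far in an assay on isolated protein for inhibition of ubiquitin carboxyl-terminal hydrolase 7 (Homo sapiens), with stated times of 30 min and 2 h; a lower number here means a stronger inhibitor, a higher number a weaker inhibitor:
Compound 1, `Cn1nc2c(=O)n(CC3(O)CCN(Cc4ccc(-c5ccco5)cc4Cl)CC3)cnc2c1-c1ccc(CO)cc1`, gives 42.5 nM.
Compound 2, `Cn1nc2c(=O)n(CC3(O)CCN(Cc4ccc(-c5ccco5)cc4Cl)CC3)cnc2c1-c1ccc(C2(N)CC2)cc1`, gives 66.1 nM.
Compound 3, `CCCNCc1ccc(-c2c3ncn(CC4(O)CCN(Cc5ccc(-c6ccco6)cc5Cl)CC4)c(=O)c3nn2C)cc1`, gives 43.9 nM.

Compound 3 stands second highest of the three numbers; its nearest neighbour is compound 1, a 1.0-fold higher number from compound 1 to compound 3 (0.01 log units; within the scatter), and its furthest is compound 2, a 1.5-fold lower number from compound 2 to compound 3 (0.18 log units; within the scatter). All three compounds share the same core and differ only in the group on the aromatic carbon of the six-membered aromatic ring of carbon only, para to a large group.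

Compound 4, `Cn1nc2c(=O)n(CC3(O)CCN(Cc4ccc(-c5ccco5)cc4Cl)CC3)cnc2c1-c1ccc(Cl)cc1`, carries the change chloro in place of (propylamino)methyl on an aromatic carbon at that same place. Within the data shown here, no measured step brings in chloro there, so the bearing steps are only those at the same position: a 1.6-fold higher number from compound 1 to compound 2 (0.19 log units; within the scatter), a 1.0-fold higher number from compound 1 to compound 3 (0.01 log units; within the scatter) and a 1.5-fold lower number from compound 2 to compound 3 (0.18 log units; within the scatter), each within the scatter. Three quite different groups at this carbon leave the number in this assay essentially unchanged, so the expectation for compound 4 is a step of no size beyond the scatter, a 1.1-fold higher number from compound 3 to compound 4 (0.06 log units; within the scatter). Compound 4 is therefore estimated at 50 nM, range 20 nM to 130 nM.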

Compound 4, half-maximal inhibitory concentration: 143 nM
The estimate for compound 4 lay 2.9-fold (0.46 log units) below the measured number, and the stated range ends below it.
By their numbers in this assay, from the lowest: compounds 1, 3 and 2 (each within the scatter of the next); then compound 4.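

Among these compounds, at this carbon, the tolerance seen in this assay among hydroxymethyl, 1-aminocyclopropyl and (propylamino)methyl does not extend to chloro, the first group here to give steps beyond the scatter: a 3.3-fold higher number from compound 3 to compound 4 (0.51 log units; beyond the scatter), a 2.2-fold higher number from compound 2 to compound 4 (0.34 log units; beyond the scatter) and a 3.4-fold higher number from compound 1 to compound 4 (0.53 log units; beyond the scatter). The position is therefore not indifferent to its substituent, and the three earlier groups, each carrying an oxygen or a nitrogen, stay within the scatter of one another while chloro, with neither atom, stands apart. No measurement shown accounts for this separation.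

A single chloro compound cannot show whether the shift belongs to chloro itself or to any group lacking oxygen and nitrogen. A methyl, a methoxy or a carboxylic acid at this carbon would test that reading.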